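This account rests on a few compounds, and the source may have more. Where it says the series, first, only, none or still open, it means among the compounds named here.

Compounds measured so far in an ADME assay on isolated protein for inhibition of protein deacetylase HDAC6 (Homo sapiens), read by fluorescence, with stated times of 5 min and 30 min; a higher number here means a weaker inhibitor, a lower number a stronger inhibitor:
- compound 1 `O=C(CNS(=O)(=O)c1cccc(C(=O)NO)c1)Nc1ccccc1`: 14100 nM
- compound 2 `O=C(NO)c1cccc(S(=O)(=O)N[C@H](C(=O)Nc2ccccc2)c2ccccc2)c1`: 6700 nM
- compound 3 `O=C(NO)c1cccc(S(=O)(=O)N[C@H](C(=O)NCc2ccccc2)c2ccccc2)c1`: 34000 nM

Compound 1 stands second highest of the three numbers; its nearest neighbour is compound 2, which gives a lower number, and compound 3 gives the highest number of the set.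

The step under consideration leads to compound 4 `C[C@H](NS(=O)(=O)c1cccc(C(=O)NO)c1)C(=O)Nc1ccccc1`, which differs from compound 1 in one place: methyl in place of hydrogen on a saturated chain carbon bound to a carbonyl carbon and a sulfonamide nitrogen.

Among the compounds with values here, only one measured step touches that same position: a 2.1-fold lower number from compound 1 to compound 2 (0.32 log units; beyond the scatter), where a far larger group enters at the same saturated chain carbon. The step of a 5.1-fold higher number from compound 2 to compound 3 (0.71 log units; beyond the scatter) concerns the amide-type nitrogen and bears only indirectly on the question, showing that the series is sensitive to changes near that end. A single carbon entering where phenyl gave a modest gain is expected to move the number little, if at all; a small shift toward a lower number, mostly within the scatter, is the working expectation, so for compound 4 the step is estimated as a 1.3-fold lower number from compound 1 to compound 4 (0.11 log units; within the scatter).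

Compound 4 is therefore expected to give about 11000 nM in this assay, with a range from 5000 nM to 25000 nM.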

Compound 4, half-maximal inhibitory concentration: 27700 nM
Compound 4: middle estimate off by 2.5-fold (0.40 log units), on the low side; the measured number lies above the stated range.
By their numbers in this assay, from the lowest: compound 2; then compounds 1, 4 and 3 (each within the scatter of the next, the first and the last beyond it).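

In this assay, methyl in place of hydrogen on the saturated chain carbon bound to a carbonyl carbon and a sulfonamide nitrogen gives a 2.0-fold higher number from compound 1 to compound 4 (0.29 log units; within the scatter), so at this position the single carbon cannot be told apart from hydrogen. Methyl and phenyl at that carbon can be told apart, with a 4.1-fold higher number from compound 2 to compound 4 (0.62 log units; beyond the scatter), so the lower number of compound 2 does not carry over to the methyl group. Nothing at hand accounts for this difference between the two groups.

On these data alone, what an ethyl, isopropyl or cyclohexyl group would give at this carbon stays open, as does how the mirror-image form at that carbon compares. Also open, as far as these compounds go, is whether methyl at this carbon gives a similar result with benzyl on the amide-type nitrogen, as in compound 3.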